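The source may report more compounds than this note shows. Statements on the series, on what has been measured and on what is new or still open speak of the compounds shown alone.

Compound 1 `CCC(C)C1NC(=O)N(C2CCCCC2)C1=O` was tested in a functional assay on HeLa cells (Homo sapiens) for inhibition; on this read-out higher numbers stand for weaker inhibition and lower numbers for stronger inhibition. In this assay compound 1 gives > 100000 nM, which is a limit of the assay and not a measured number. Compound 2 `CCC(C)C(NC(=O)NO)C(=O)NCc1ccccc1` likewise gives > 100000 nM in this assay, a limit. Compound 3 `CCC(C)C(NC(=O)n1nnc2ccccc21)C(=O)NCc1ccccc1` gives >= 100000 nM in this assay, also a limit. Within the data shown here, the only step among the measured compounds, a step that the two limits leave unreadable from compound 2 to compound 3, stays unreadable because the limit of > 100000 nM in this assay, at which 2 of the 3 values shown sit, and the limit of >= 100000 nM in this assay, at which 1 of the 3 values shown sits, provide no numbers that could be set against each other. So compound 1 stands where the other two stand: at the edge of what this assay can report, with no inhibition resolved.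

Compound 4 `CC(C)C1NC(=O)N(C2CCCCC2)C1=O` differs from compound 1 by hydrogen in place of methyl on a saturated chain carbon, two bonds along the chain from a saturated ring carbon; cut one bond further out, sec-butyl becomes isopropyl. Among the measured compounds shown here, none of the measured steps touches this place, and none of them yields a readable size, so nothing here points to a direction of change. The expected step is estimated as a number no higher from compound 1 to compound 4 (the limit leaves the size open), which means no change beyond the scatter. For compound 4 the estimate in this assay is 100000 nM, with an expected range from 40000 nM to 300000 nM.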

Compound 4, half-maximal inhibitory concentration: > 100000 nM
Compound 4 ended at the assay's limit (the forecaster's own chance of this, stated with the estimate: 85%); the middle value lies on the limit itself.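

The step from sec-butyl to isopropyl, going from compound 1 to compound 4, cannot be read, because both compounds stand at the same limit in this assay: the limit of > 100000 nM in this assay, at which 3 of the 4 values shown sit.

The compounds shown leave open whether any change to these structures would give a measured number in this assay, and so which groups matter for inhibition.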